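A few compounds are considered here, and "the series" means these few. Any claim that something is new, unique, unknown or untested is made for them only; others in the source may bear on it.

Compound 1, `CNC(=O)CC1CCc2cc(OC)c(OC)cc21`: 21.2%
Compound 2, `CCNC(=O)CC1CCc2cc(OC)c(OC)cc21`: 23.6%
Compound 3, `CCCNC(=O)CC1CCc2cc(OC)c(OC)cc21`: 26.9%

All three were tested in a functional assay on the whole organism (strain Swiss albino) for inhibition, with Mus musculus as the target, in the writhing test, with stated times of 60 min and 15 min, at a dose of 100 mg/kg by the oral route; a lower number here means less inhibition, a higher number more inhibition at the dose given (going by the name of the read-out). Compound 2 gives 23.6%, the second highest of the three numbers; its nearest neighbour, compound 1, gives 21.2%, and compound 3 gives 26.9%. Every step among these three stays within the scatter: a number 2.4 percentage points higher from compound 1 to compound 2 (within the scatter), a number 5.7 percentage points higher from compound 1 to compound 3 (within the scatter) and a number 3.3 percentage points higher from compound 2 to compound 3 (within the scatter). Growing the chain on the amide-type nitrogen from hydrogen through methyl to ethyl thus does not move the number beyond what repeated measurement alone would show.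

Compound 4, `COc1cc2c(cc1OC)C(CC(=O)N1CCNCC1)CC2`, has not yet been measured. It differs from compound 2 in one place: piperazin-1-yl in place of ethylamino on a carbonyl carbon. Among the compounds with values here, the three measured steps all alter the same chain on the amide-type nitrogen, so they are the only guide available, and each of them was small. The piperazin-1-yl group, with its six-membered non-aromatic ring, is a larger change than any of those, but nothing measured here points in either direction. The step from compound 2 to compound 4 is therefore expected to be a number 1.4 percentage points higher from compound 2 to compound 4 (within the scatter), with no movement beyond the scatter. Compound 4 is expected to give 25%, with a range from 10% to 42%.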

Compound 4, a percentage reported as inhibition, in the whole organism at one dose (the size of the read-out at that dose, not a potency): 68.8%
Compound 4: middle estimate off by 43.8 percentage points, on the low side; measured number above the stated range.
By their numbers in this assay, from the lowest: compounds 1, 2 and 3 (each within the scatter of the next); then compound 4.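

In this assay, placing piperazin-1-yl on the carbonyl carbon gives a number 45.2 percentage points higher from compound 2 to compound 4 (beyond the scatter), while a number 41.9 percentage points higher from compound 3 to compound 4 (beyond the scatter) and a number 47.6 percentage points higher from compound 1 to compound 4 (beyond the scatter) tell the same story from the two other open-chain amides. The earlier compounds shown here changed only the length of a chain and left the read-out within its usual scatter, so this position looked insensitive; these steps show that the group on the carbonyl carbon can matter a great deal when the open chain gives way to a six-membered non-aromatic ring with 2 hetero atoms. No measurement here accounts for the jump.

The change brings in a ring, more heavy atoms and a further nitrogen all at once, so the compounds shown cannot separate these features, whereas a piperidin-1-yl amide, with the ring but no further nitrogen, or a morpholin-4-yl amide, with oxygen in that place, would help to do so. Also open, from the compounds shown here alone, is whether the ring nitrogen can carry a substituent, such as the methyl of a 4-methylpiperazin-1-yl amide, without losing the higher number.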